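The source may hold more compounds than are shown below. What is called first, only, known or untested is meant among the compounds shown, and "the series" means these compounds.

Measured compounds:
Compound 1 `CC(=O)N1c2ccccc2CCC1C(=O)Nc1cc(C(F)(F)F)cc(C(F)(F)F)c1` gives > 70000 nM in a functional assay on HCT-15 cells (Homo sapiens) for cytotoxicity, read by sulforhodamine B assay, with a stated time of 72 h (on this read-out lower numbers stand for stronger inhibition of growth and higher numbers for weaker inhibition of growth), and this is a limit of the assay rather than a number.
Compound 2 `O=C(Nc1ccccc1C(F)(F)F)C1CCc2ccccc2N1` gives 40400 nM in this assay.

Compound 1 therefore stands only at a limit: its inhibition of growth was too weak to yield a number, and the limit of > 70000 nM in this assay, at which 1 of the 2 values shown sits, shows that one of the two values recorded sits there. Among the compounds with values here, compound 2 differs from compound 1 in more than one place, so no single step between them can be read; it simply shows a measurable number. Compound 3 `O=C(Nc1cc(C(F)(F)F)cc(C(F)(F)F)c1)C1CCc2ccccc2N1C(=O)c1cccc(Cl)c1` differs from compound 1 by 3-chlorophenyl in place of methyl on a carbonyl carbon, which one bond further out reads acetyl to (3-chlorophenyl)carbonyl. Within the data shown here, no measured pair shows this change, so its effect in this assay is unknown, and with compound 1 at a limit only a gain beyond the scatter would bring compound 3 into the measurable range. Compound 3 is expected to give 50000 nM, between 15000 nM and 150000 nM. This amounts to an expected step of an at least 1.4-fold lower number from compound 1 to compound 3 (0.14 log units; that floor lies within the scatter), itself uncertain.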

Compound 3, concentration for 50% growth inhibition: 625 nM
For compound 3 the middle estimate is 80-fold (1.90 log units) above the measured one; measured number outside the range, below it.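

On the carbonyl carbon whose other neighbour is the amide-type nitrogen in a ring, 3-chlorophenyl in place of methyl gives an at least 110-fold lower number from compound 1 to compound 3 (2.04 log units; beyond the scatter) in this assay. Within the data shown here, this is the first reading of any change at this place, and it shows that replacing a single carbon with a much larger aromatic group can bring growth inhibition into the measurable range, with compound 3 far stronger than compound 1. Compound 1 holds a limit of the assay and not a number, so the step is only a floor: the limit of > 70000 nM in this assay, at which 1 of the 3 values shown sits.

The compounds shown do not tell whether the ring alone carries this gain or whether the chlorine is also needed, as a plain phenyl would show. As far as these compounds go, how an amine or a longer alkyl chain would fare at this carbon also stays open.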